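This account rests on a few compounds, and the source may have more. Where it says the series, first, only, none or still open, it means among the compounds named here.

In a functional assay on MDA-MB-436 cells (Homo sapiens) for antiproliferative activity, read by MTT assay, with a stated time of 24 h (on this read-out lower numbers stand for stronger inhibition and higher numbers for weaker inhibition), compound 1 (`N#Cc1ccc(S(=O)(=O)NC(CC(=O)O)c2ccccc2)cc1`) gives 59300 nM. Compound 2 (`O=C(O)CC(NS(=O)(=O)c1ccccc1)c1ccccc1F`) has only a limit, > 100000 nM, so its position on the scale has no number. Compound 3 (`N#Cc1ccc(S(=O)(=O)NC(CC(=O)O)c2ccccc2F)cc1`) differs from compound 2 by cyano in place of hydrogen on an aromatic carbon, giving a 4-cyanophenyl in place of a phenyl. Among the compounds with values here, no measured pair isolates this change in this assay. Within the data shown here, the only guide is compound 1, which also carries the 4-cyanophenyl, at 59300 nM. A modest move towards stronger inhibition is expected, with an estimated at least 1.6-fold lower number from compound 2 to compound 3 (0.22 log units; that floor lies within the scatter). For compound 3 the expected value is 60000 nM, within an estimated range of 25000 nM to 130000 nM.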

Compound 3, half-maximal inhibitory concentration: 77700 nM
Estimate against measurement, compound 3: 1.3-fold (0.11 log units) below, and the stated range covers the measured number.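

With the 4-cyanophenyl held constant, the added fluoro gives a 1.3-fold higher number from compound 1 to compound 3 (0.12 log units; within the scatter), so in this assay this change cannot be told apart from no change. Cyano in place of hydrogen, para to a large group, gives an at least 1.2-fold lower number from compound 2 to compound 3 (0.10 log units; that floor lies within the scatter), and that step is only a floor. Compound 2 stands at a limit of the assay, not at a number: the limit of > 100000 nM in this assay, at which 1 of the 3 values shown sits.

Still open, on these data alone, is whether an amine or a trifluoromethyl in place of the cyano would shift the number beyond the scatter. Also open, as far as these compounds go, is what a methyl ester in place of the carboxylic acid would do.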